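The source may hold more compounds than are shown below. What is called first, only, known or untested is meant among the compounds shown, and "the series" means these compounds.

Measured in a functional assay on HCT-116 cells (Homo sapiens), read by sulforhodamine B assay, with a stated time of 5 days; on this read-out lower numbers stand for stronger inhibition of growth and higher numbers for weaker inhibition of growth:
Compound 1 `OC[C@H]1O[C@@H](n2cc(F)c3c(-c4ccccc4)ncnc32)[C@H](O)[C@@H]1O`: > 10000 nM
Compound 2 `OC[C@H]1O[C@@H](n2cc(F)c3c(-c4cccs4)ncnc32)[C@H](O)[C@@H]1O`: 9 nM
Compound 3 `OC[C@H]1O[C@@H](n2cc(F)c3c(-c4ccc[nH]4)ncnc32)[C@H](O)[C@@H]1O`: 450 nM

The value of compound 1 is a limit of the assay and not a number (the limit of > 10000 nM in this assay, at which 1 of the 3 values shown sits). Among the actual numbers, compound 2 stands lowest at 9 nM, and the nearest is compound 3 at 450 nM.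

The next compound is compound 4 `OC[C@H]1O[C@@H](n2cc(F)c3c(-c4ccoc4)ncnc32)[C@H](O)[C@@H]1O`. It carries furan-3-yl in place of thiophen-2-yl on an aromatic carbon.

All three measured steps exchange the ring at this same place, and all are large: an at least 1100-fold lower number from compound 1 to compound 2 (3.04 log units; beyond the scatter), an at least 22-fold lower number from compound 1 to compound 3 (1.34 log units; beyond the scatter) and a 50-fold higher number from compound 2 to compound 3 (1.70 log units; beyond the scatter). The last bears most directly, as it is the only measured replacement of the thiophen-2-yl by another five-membered aromatic ring, and it raised the number. A move in the same direction is therefore expected for compound 4, though a smaller one, and it may not clear the scatter: a 3.3-fold higher number from compound 2 to compound 4 (0.52 log units; beyond the scatter) is the estimated step. For compound 4 the expected value in this assay is 30 nM, with an estimated range of 8 nM to 200 nM.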

Compound 4, concentration for 50% growth inhibition: 18 nM
The estimate for compound 4 lay 1.7-fold (0.22 log units) above the measured number; low and high end bracket the measured number.
By their numbers in this assay, from the lowest: compounds 2 and 4 (each within the scatter of the next); then compound 3. At a limit, above all of these: compound 1.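

In this assay, the step from thiophen-2-yl to furan-3-yl is a 2.0-fold higher number from compound 2 to compound 4 (0.30 log units; within the scatter), so this position tolerates a second five-membered aromatic ring with one hetero atom, even with oxygen for sulfur and a different point of attachment. Not every such ring matches this, as replacing the 1H-pyrrol-2-yl gives a 25-fold lower number from compound 3 to compound 4 (1.40 log units; beyond the scatter). Replacing the phenyl gives an at least 550-fold lower number from compound 1 to compound 4 (2.74 log units; beyond the scatter), a step that starts from a limit of the assay and not a number: the limit of > 10000 nM in this assay, at which 1 of the 4 values shown sits.

On these data alone, what furan-2-yl or thiophen-3-yl would give at this place remains open, so the roles of the hetero atom and the point of attachment cannot be separated. Also open, as far as these compounds go, is whether a pyridin-3-yl ring, or a methyl group on the thiophene ring, would fit this position.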